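Swapping an isopropoxy group for an arylamine in a weak antiproliferative series

The source may report more compounds than this note shows. Statements on the series, on what has been measured and on what is new or still open speak of the compounds shown alone.

Compound 1 `CC(C)OC1=C(C(=O)c2ccccc2)C(c2ccc(Br)cc2)N(CCCn2ccnc2)C1=O` is tested in a functional assay on NCI-H1299 cells (Homo sapiens) for antiproliferative activity, read by MTT assay, with a stated time of 72 h (a lower number here means a stronger inhibitor, a higher number a weaker inhibitor), where compound 1 gives 18900 nM. Among the three measured compounds this is the lowest number, although the others sit within the usual scatter of it. Compound 2 `CCOc1ccc(NC2=C(C(=O)c3ccccc3)C(c3ccc(Br)cc3)N(CCCn3ccnc3)C2=O)cc1` gives 20000 nM and compound 3 `O=C(C1=C(Nc2ccc(Cl)cc2)C(=O)N(CCCn2ccnc2)C1c1ccc(Br)cc1)c1ccccc1` gives 25000 nM. The change a 1.1-fold higher number from compound 1 to compound 2 (0.02 log units; within the scatter) and the change a 1.3-fold higher number from compound 1 to compound 3 (0.12 log units; within the scatter) both stay within the scatter, as does the change a 1.3-fold higher number from compound 2 to compound 3 (0.10 log units; within the scatter).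

Compound 4 `O=C(C1=C(Nc2ccc(OC(F)(F)F)cc2)C(=O)N(CCCn2ccnc2)C1c1ccc(Br)cc1)c1ccccc1` differs from compound 1 in one place: (4-(trifluoromethoxy)phenyl)amino in place of isopropoxy on a double-bonded ring carbon. The two measured steps that bear on it are the same kind of exchange, an arylamine with a substituted phenyl ring replacing the isopropoxy group, and neither moved the number beyond the scatter. Among the compounds with values here, no measured step therefore points to a shift, in either direction, for compound 4. The expected step for compound 4 is a 1.2-fold higher number from compound 1 to compound 4 (0.07 log units; within the scatter), which means compound 4 is estimated at 22000 nM, with a range from 10000 nM to 50000 nM.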

Compound 4, half-maximal inhibitory concentration: 11500 nM
For compound 4 the middle estimate is 1.9-fold (0.28 log units) above the measured one; the range from low to high includes it.
By their numbers in this assay, from the lowest: compounds 4, 1, 2 and 3 (each within the scatter of the next, the first and the last beyond it).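

Within the data shown here, on the phenyl ring of the arylamine, trifluoromethoxy in place of chloro gives the only step in this short series that lies beyond the scatter in this assay, and it is a modest one: a 2.2-fold lower number from compound 3 to compound 4 (0.34 log units; beyond the scatter). The steps of a 1.6-fold lower number from compound 1 to compound 4 (0.22 log units; within the scatter) and a 1.7-fold lower number from compound 2 to compound 4 (0.24 log units; within the scatter) both stay within the scatter, so neither replacing isopropoxy with this arylamine nor exchanging ethoxy for trifluoromethoxy on the ring gives a clear difference. Among these compounds, no measurement here offers an explanation for the one step beyond the scatter.

The compounds shown leave open whether a nitrile or a dimethylamino group on the phenyl ring would give a larger step. They also leave open where an unsubstituted phenylamino group or a cyclohexylamino group would fall among these values.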